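This account rests on a few compounds, and the source may have more. Where it says the series, first, only, none or still open, it means among the compounds named here.

Of the compounds shown here, three with a shared core have been measured for solubility. In a physicochemical assay for solubility, in phosphate buffer, with a stated time of 24 h, at pH 7.4, tested at 100 uM (on this read-out lower numbers stand for lower solubility and higher numbers for higher solubility), compound 3 `CC(=O)N1CCC(S(=O)(=O)c2ccc(CNC(=O)N3Cc4ccncc4C3)cc2)CC1` gives 187000 nM. Compound 1 `O=C(NCc1ccc(S(=O)(=O)c2ccccc2)cc1)N1Cc2ccncc2C1` gives 115000 nM in this assay, and the step of a 1.6-fold higher number from compound 1 to compound 3 (0.21 log units; within the scatter) lies within the scatter of repeated measurements, so the two cannot be told apart on this read-out. Compound 2 `O=S(=O)(c1ccccc1)c1ccc(CNS(=O)(=O)N2Cc3ccncc3C2)cc1`, in which a sulfonyl-bearing nitrogen replaces the urea carbonyl of the core, gives 3000 nM in this assay, far below the other two and well beyond the scatter.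

Compound 4 `O=C(NCc1ccc(S(=O)(=O)N2CC3(CCOCC3)C2)cc1)N1Cc2ccncc2C1` differs from compound 3 as follows: a group of 9 heavy atoms (7 carbon, 1 nitrogen, 1 oxygen; one four-membered non-aromatic ring with 1 hetero atom, one six-membered non-aromatic ring with 1 hetero atom) in place of a group of 9 heavy atoms (7 carbon, 1 nitrogen, 1 oxygen; one six-membered non-aromatic ring with 1 hetero atom), on a sulfonyl sulfur. For the measured compounds named here, the only measured step that touches the group on the sulfonyl sulfur is the one from compound 1 to compound 3, and it stayed within the scatter, which suggests that the part of the molecule on this sulfur does not move solubility much. Going by the values given here, no measured compound carries the ring pair that enters in compound 4, so the expectation rests on that single step and on the shared count of atoms.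

For compound 4 the estimated step of a 1.6-fold lower number from compound 3 to compound 4 (0.19 log units; within the scatter) is expected to stay within the scatter. Compound 4 is therefore expected to give about 120000 nM in this assay, most likely between 40000 nM and 250000 nM.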

Compound 4, solubility: 272000 nM
Compound 4: middle estimate off by 2.3-fold (0.36 log units), on the low side; measured number outside the range, above it.
By their numbers in this assay, from the lowest: compound 2; then compounds 1, 3 and 4 (each within the scatter of the next, the first and the last beyond it).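

In this assay, the same atoms joined differently on the sulfonyl sulfur, with 1-acetylpiperidin-4-yl leaving and a group with a four-membered and a six-membered non-aromatic ring entering, give a 1.5-fold higher number from compound 3 to compound 4 (0.16 log units; within the scatter) and so leave the two compounds indistinguishable on this read-out. For the compounds shown here, measured against phenyl, the group that enters gives a 2.4-fold higher number from compound 1 to compound 4 (0.37 log units; beyond the scatter) and this is the first step at this position to pass the scatter, though only modestly, while compound 3 stays within the scatter of both compound 1 and compound 4. Nothing available here offers a measured reason for these small steps.

The compounds shown leave open how this assay responds to quite different groups on this sulfur, such as a longer alkyl chain, a simple amine or a carboxylic acid. They also leave open whether the two-ring group would give a similar reading on the sulfonyl-bearing nitrogen form of the core seen in compound 2, whose number is far below the others.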